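The source may report more compounds than this note shows. Statements on the series, on what has been measured and on what is new or still open speak of the compounds shown alone.

Measured so far:
compound 1 `COC(=O)c1ccc(CN2C(=O)/C(=C/c3cc(C)n(-c4ccc(O)c(C(=O)O)c4)c3C)SC2=S)cc1` — 36900 nM
compound 2 `Cc1cc(/C=C2\SC(=S)N(Cc3cccc(Br)c3)C2=O)c(C)n1-c1ccc(O)c(C(=O)O)c1` — 48200 nM
compound 3 `COc1cccc(CN2C(=O)/C(=C/c3cc(C)n(-c4ccc(O)c(C(=O)O)c4)c3C)SC2=S)c1` — 102000 nM

In an ADME assay on MT2 cells (Homo sapiens) for cytotoxicity, read by XTT assay, with a stated time of 4 days (a lower number here means that less compound is tolerated, a higher number that more compound is tolerated), compound 3 stands highest of the three: a 2.8-fold higher number from compound 1 to compound 3 (0.44 log units; beyond the scatter) and a 2.1-fold higher number from compound 2 to compound 3 (0.33 log units; beyond the scatter) are both beyond the scatter, the steps being modest. Compound 4 `Cc1cc(/C=C2\SC(=S)N(Cc3ccccc3Br)C2=O)c(C)n1-c1ccc(O)c(C(=O)O)c1` is the next member; its change from compound 3 is 2-bromophenyl in place of 3-methoxyphenyl on a saturated chain carbon bound to an amide-type nitrogen in a ring. The step of a 2.1-fold higher number from compound 2 to compound 3 (0.33 log units; beyond the scatter) is the one that bears on this change most directly, since it exchanged methoxy for bromo on an aromatic carbon; the step of a 1.3-fold higher number from compound 1 to compound 2 (0.12 log units; within the scatter) lies within the scatter. Going by the values given here, no measured pair tells how 2-bromobenzyl compares with 3-bromobenzyl. A modest lower number is therefore expected, about the size of the reverse of that methoxy-for-bromo step, as a 2.0-fold lower number from compound 3 to compound 4 (0.31 log units; beyond the scatter). Compound 4 is estimated at 50000 nM, with a range of 25000 nM to 100000 nM.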

Compound 4, half-maximal cytotoxic concentration: 25700 nM
Compound 4: the middle estimate sits 1.9-fold (0.29 log units) above what was measured; the range from low to high includes it.
By their numbers in this assay, from the lowest: compounds 4, 1 and 2 (each within the scatter of the next); then compound 3.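

In this assay, the change to 2-bromophenyl gives a 4.0-fold lower number from compound 3 to compound 4 (0.60 log units; beyond the scatter), so 3-methoxyphenyl now stands apart from all three other groups at this position. By contrast, 2-bromophenyl and 3-bromophenyl are not separated, at a 1.9-fold lower number from compound 2 to compound 4 (0.27 log units; within the scatter), and neither are 2-bromophenyl and 4-(methoxycarbonyl)phenyl, at a 1.4-fold lower number from compound 1 to compound 4 (0.16 log units; within the scatter). No available evidence accounts for the standing of compound 3.

On these data alone, whether 2-methoxyphenyl would match 3-methoxyphenyl stays open, as does the outcome for an amine or a carboxylic acid on this phenyl ring.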